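Notes on the step from compound 3 to compound 4

The compounds below may be only part of what the source reports. "The series", "measured", "known", "first", "only" and "open" are said of these compounds alone.

Measured in a functional assay on HT-29 cells (Homo sapiens) for inhibition; a lower number here means a stronger inhibitor, a higher number a weaker inhibitor:
- compound 1 `FC(F)(F)Oc1cccc(/C=C\c2ccc3ccccc3c2)c1` gives 3500 nM
- compound 2 `COc1cc(/C=C/c2ccc3c(ccn3S(=O)(=O)c3ccccc3)c2)cc(OC)c1OC` gives > 5000 nM (a limit)
- compound 3 `COc1cc(/C=C\c2ccc3c(ccn3S(=O)(=O)c3ccccc3)c2)cc(OC)c1OC` gives > 5000 nM (a limit)

Compound 3 is known only as a limit of > 5000 nM. Within the data shown here, the series so far rests largely on (the limit of > 5000 nM in this assay, at which 2 of the 3 values shown sit). Compound 4 `COc1cc(/C=C\c2ccc3[nH]ccc3c2)cc(OC)c1OC` follows from compound 3 with hydrogen in place of phenylsulfonyl on an aromatic nitrogen. Among the measured compounds shown here, the only measured step is a step that the two limits leave unreadable from compound 2 to compound 3, and it rests on (the fact that compounds 2 and 3 differ only in the configuration as drawn), so it gives no size for this change. A readable value for compound 4 is expected to lie on the stronger side of compound 3 at > 5000 nM. The estimated step, loosely sized, is an at least 12-fold lower number from compound 3 to compound 4 (1.09 log units; beyond the scatter). For compound 4 the estimate is 400 nM, with an expected range from 30 nM to 5000 nM.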

Compound 4, half-maximal inhibitory concentration: 35 nM
Beside the measured number, compound 4's estimate is 11-fold (1.06 log units) above it, and the stated range covers the measured number.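

In this assay, hydrogen in place of phenylsulfonyl on an aromatic nitrogen gives an at least 140-fold lower number from compound 3 to compound 4 (2.15 log units; beyond the scatter), the first readable size for any change in this series, as the earlier step between double-bond configurations cannot be read. This size is only a minimum, since the step starts from a limit: the limit of > 5000 nM in this assay, at which 2 of the 4 values shown sit.

Open, from the compounds shown here alone, is whether a methyl or an acetyl group on this nitrogen stays near compound 4 or moves toward compound 3. Also open, going by these compounds, is how far double-bond configuration counts with hydrogen on this nitrogen.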